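From Phenyl to Cyclopentyl: Expected Loss of Cytotoxicity

A few compounds are considered here, and "the series" means these few. Any claim that something is new, unique, unknown or untested is made for them only; others in the source may bear on it.

Compound 1, `COc1ccc(Nc2cc(C)oc(=O)c2)cc1`, in a functional assay on DU-145 cells (Homo sapiens) for cytotoxicity, read by MTT assay, with a stated time of 72 h (a higher number here means that more compound is needed for the effect, a lower number that less compound is needed), gives only a limit, > 30 uM.
Compound 2, `COc1ccc(Nc2cc(C3CCCCC3)oc(=O)c2)cc1`, in this assay gives 8.61 uM.
Compound 3, `COc1ccc(Nc2cc(-c3ccccc3)oc(=O)c2)cc1`, in this assay gives 0.12 uM.

Compound 3 has the lowest number of the two measured values, the next being compound 2, with a 72-fold lower number from compound 2 to compound 3 (1.86 log units; beyond the scatter). Compound 4, `COc1ccc(Nc2cc(C3CCCC3)oc(=O)c2)cc1`, differs from compound 3 by cyclopentyl in place of phenyl on an aromatic carbon. The relevant measured steps are a 72-fold lower number from compound 2 to compound 3 (1.86 log units; beyond the scatter) and an at least 250-fold lower number from compound 1 to compound 3 (2.39 log units; beyond the scatter), both large and both favouring phenyl over a saturated substituent. A step back to a saturated ring is therefore expected to raise the number considerably in this assay. Compound 4 is estimated at 6 uM, between 1.5 uM and 25 uM, which means an expected 50-fold higher number from compound 3 to compound 4 (1.70 log units; beyond the scatter).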

Compound 4, concentration for half-maximal effect: 5.42 uM
Compound 4: middle estimate off by 1.1-fold (0.04 log units), on the high side, and the stated range covers the measured number.
By their numbers in this assay, from the lowest: compound 3; then compounds 4 and 2 (each within the scatter of the next). At a limit, above all of these: compound 1.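

With a 45-fold higher number from compound 3 to compound 4 (1.65 log units; beyond the scatter), a second saturated ring now falls on the same side of phenyl as cyclohexyl, so at this carbon next to the ring oxygen the low number belongs to phenyl, not to just any ring. Between the two saturated rings, a 1.6-fold lower number from compound 2 to compound 4 (0.20 log units; within the scatter), so cyclopentyl and cyclohexyl cannot be told apart here. Compound 1 gives only a limit, so an at least 5.5-fold lower number from compound 1 to compound 4 (0.74 log units; beyond the scatter) is a bound and no more: the limit of > 30 uM in this assay, at which 1 of the 4 values shown sits.

The compounds shown leave open whether another aromatic ring, such as pyridyl, would keep the low number of compound 3. They also leave open what an amine on that phenyl would do.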